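The source may hold more compounds than are shown below. What is called first, only, known or untested is meant among the compounds shown, and "the series" means these compounds.

Measured compounds:
compound 1 `Nc1scc(CN2CCN(c3ccc(F)cc3Cl)CC2)c1C(=O)c1ccc(Cl)cc1`: 0%
compound 2 `COc1ccc(N2CCN(Cc3csc(N)c3C(=O)c3ccc(Cl)cc3)CC2)cc1`: 0%
compound 3 `Nc1scc(CN2CCN(C3CCCC3)CC2)c1C(=O)c1ccc(Cl)cc1`: 3%

In an assay on CHO cells for displacement of a labelled ligand from adenosine receptor A3 (Homo sapiens), read by scintillation counting, with a stated time of 120 min, tested at 10 uM (a higher number here means more inhibition at the concentration tested (going by the name of the read-out), a lower number less inhibition), none of the three stands apart: the step of a number 3 percentage points higher from compound 1 to compound 3 (within the scatter) and the step of a number 3 percentage points higher from compound 2 to compound 3 (within the scatter) both lie within the scatter, as does no change at the digits printed from compound 1 to compound 2 (within the scatter), so compound 3 is not separated from compound 1 or compound 2. Compound 4 `Nc1scc(CN2CCN(c3cccc4ccccc34)CC2)c1C(=O)c1ccc(Cl)cc1` differs from compound 3 by naphthalen-1-yl in place of cyclopentyl on an amine nitrogen in a ring. Among the measured compounds shown here, the steps that bear on this are those exchanging an aryl group for cyclopentyl at the same ring nitrogen, a number 3 percentage points higher from compound 1 to compound 3 (within the scatter) and a number 3 percentage points higher from compound 2 to compound 3 (within the scatter), both flat; going back to an aromatic group, here naphthalen-1-yl, is therefore not expected to move the number beyond the scatter. The step of no change at the digits printed from compound 3 to compound 4 (within the scatter) is estimated as essentially none. Compound 4 is expected to give 3%, range -8% to 15%.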

Compound 4, a percentage reported as inhibition, at one concentration (the size of the read-out at that concentration, not a potency): 0%
The estimate for compound 4 lay 3 percentage points above the measured number; measured number inside the range.
By their numbers in this assay, from the lowest: compounds 1, 2, 4 and 3 (each within the scatter of the next).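

In this assay, naphthalen-1-yl, with its 2 six-membered aromatic rings, gives a number 3 percentage points lower from compound 3 to compound 4 (within the scatter). In place of the single-ring aryl groups it gives no change at the digits printed from compound 2 to compound 4 (within the scatter) and no change at the digits printed from compound 1 to compound 4 (within the scatter), so the change at this ring nitrogen, now extended to a group of 10 heavy atoms, separates none of the four compounds. No supporting data bear on why the numbers stay together.

Open, as far as these compounds go, is whether a benzyl group or a longer chain ending in a carboxylic acid at this nitrogen would separate from these compounds in this assay. Changes elsewhere on the shared core also remain open.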